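Ethoxy in place of chloro on a pyrazine hydrazone

This account rests on a few compounds, and the source may have more. Where it says the series, first, only, none or still open, it means among the compounds named here.

Compound 1 `O=C(N/N=C/c1ccccc1Cl)c1cnccn1`: 69%
Compound 2 `O=C(N/N=C/c1cccc(Cl)c1)c1cnccn1`: 100%
Compound 3 `O=C(N/N=C/c1ccc(Br)cc1)c1cnccn1`: 94%

Three compounds built on a shared core were measured in an ADME assay on J774 cells (Mus musculus) for cytotoxicity, read by MTT assay, with a stated time of 48 h, tested at 150 ug/mL; on this read-out lower numbers stand for a stronger effect and higher numbers for a weaker effect at the one concentration tested. Compound 1 gives 69% in this assay, compound 2 gives 100%, and compound 3 gives 94%. Compound 2 has the highest number of the three; compound 3 lies within the usual scatter of it, so no order can be read between those two, while compound 1 sits well beyond the scatter below compound 2.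

Compound 4 `CCOc1cccc(/C=N/NC(=O)c2cnccn2)c1` differs from compound 2 in one place: ethoxy in place of chloro on an aromatic carbon. Among the measured compounds shown here, no measured pair differs in only this way, so nothing measured tells the size of this step. The expected step is a number 8 percentage points lower from compound 2 to compound 4 (within the scatter), a modest lowering at most and possibly none beyond the scatter. Compound 4 is therefore expected to give 92% in this assay, with a range from 70% to 100%. This expectation rests on compound 2, which gives 100%, the highest number reached so far, and on the lack of any measured step for the change.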

Compound 4, a percentage reported as activity, at one concentration (the size of the read-out at that concentration, not a potency): 69%
Beside the measured number, compound 4's estimate is 23 percentage points above it; measured number outside the range, below it.
By their numbers in this assay, from the lowest: compounds 1 and 4 (each within the scatter of the next); then compounds 3 and 2 (each within the scatter of the next).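

Ethoxy in place of chloro on an aromatic carbon, meta to a large group, gives a number 31 percentage points lower from compound 2 to compound 4 (beyond the scatter) in this assay and is the only measured step among these compounds. It shows that a single change at this position can move the number well beyond the usual scatter, something compounds 1, 2 and 3 could not show, as no two of them differ in only one place. Nothing available accounts for the size of this step.

The compounds shown leave open whether methoxy or a longer chain such as propoxy at this same position would give a step of similar size, or whether an amine or a hydroxyl group there would do so. They also leave open whether ethoxy would lower the number at the places held by chloro in compound 1 or bromo in compound 3.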